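Working notes on the shared core: the step to compound 4

This account rests on a few compounds, and the source may have more. Where it says the series, first, only, none or still open, it means among the compounds named here.

Measured so far in a toxicity assay on THP-1 cells (Homo sapiens) for inhibition; a lower number here means that less compound is tolerated, a higher number that more compound is tolerated:
- Compound 1 `Cn1c(-c2ccccc2)cnc1NC(=O)c1cccc(Cl)c1` gives > 50000 nM, a limit of the assay.
- Compound 2 `Cn1c(-c2ccccc2Br)cnc1NC(=O)c1ccc(F)cc1` gives > 100000 nM, a limit of the assay.
- Compound 3 `Cn1c(-c2ccccc2Cl)cnc1NC(=O)c1ccc(F)cc1` gives > 50000 nM, a limit of the assay.

No value in this set is a number; every compound sits at a limit. Compound 3 stands at the limit of > 50000 nM in this assay, at which 2 of the 3 values shown sit. Compound 2 stands at the limit of > 100000 nM in this assay, at which 1 of the 3 values shown sits. Among the compounds with values here, the one measured single-point step, a step that the two limits leave unreadable from compound 2 to compound 3, cannot be read, and the gap between compound 1 and compound 3 is likewise only two limits.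

Compound 4 `Cn1c(-c2ccccc2)cnc1NC(=O)c1ccc(F)cc1` differs from compound 3 by hydrogen in place of chloro on an aromatic carbon. Within the data shown here, no measured step bears on this change directly, and the step that exists is unreadable, so no shift beyond the scatter is expected in this assay in either direction. Compound 4 is expected to be tolerated at about 70000 nM, within 30000 nM to 200000 nM, most probably reported again as a limit. The expected step from compound 3 is a step that the limit leaves unreadable from compound 3 to compound 4.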

Compound 4, half-maximal cytotoxic concentration: > 100000 nM
Compound 4: only a limit was reported; the forecaster's own chance of this, stated with the estimate: 85%; middle value at least 1.4-fold (0.15 log units) away from the limit.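

In this assay compound 4 is reported only as a limit, as are compound 1, compound 2 and compound 3, and none of the steps to compound 4 can be read. The compounds shown leave open where any of these four would give an actual value in this assay, and whether chloro, bromo or hydrogen on the aromatic ring makes any difference there.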